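Isopropyl for phenyl on the saturated ring of compound 1

The source may hold more compounds than are shown below. What is called first, only, known or untested is meant among the compounds shown, and "the series" means these compounds.

Measured so far in a functional assay for antagonist activity at P2X purinoceptor 7 (Rattus norvegicus), read by FLIPR and calcium flux; on this read-out lower numbers stand for stronger inhibition and higher numbers for weaker inhibition:
compound 1 `Cc1ccccc1N/C(=N\C#N)N1CCN(C(=O)Nc2ccc(Cl)cc2)C(c2ccccc2)C1`, compound 1 gives 95 nM
compound 2 `Cc1ccccc1NC(=O)N1CCN(C(=O)Nc2ccc(Cl)cc2)C(c2ccccc2)C1`, compound 2 gives 620 nM

Compound 1 stands at the lower of the two numbers in this assay. Compound 2, which carries a urea linkage where compound 1 carries the cyanoguanidine, gives the higher number, and the gap between the two lies beyond the usual scatter of repeated measurements. Only these two points exist, so nothing is known yet about how the substituent on the saturated ring carbon affects the read-out.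

Compound 3 `Cc1ccccc1N/C(=N\C#N)N1CCN(C(=O)Nc2ccc(Cl)cc2)C(C(C)C)C1` keeps the cyanoguanidine and the (4-chlorophenyl)carbamoyl group of compound 1 and differs in one place: isopropyl in place of phenyl on a saturated ring carbon. Among the compounds with values here, there is no measured pair that shows a change of this kind, so the expectation rests on the structural change alone. Within the data shown here, the step from compound 1 to compound 3 is expected to weaken inhibition, a 5.3-fold higher number from compound 1 to compound 3 (0.72 log units; beyond the scatter), with the range kept wide since no comparable pair has been measured. Compound 3 is accordingly estimated at 500 nM, with a plausible span from 120 nM to 2500 nM.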

Compound 3, half-maximal inhibitory concentration: 110 nM
Beside the measured number, compound 3's estimate is 4.5-fold (0.66 log units) above it; the measured number lies below the stated range.
By their numbers in this assay, from the lowest: compounds 1 and 3 (each within the scatter of the next); then compound 2.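

In this assay the exchange of phenyl for isopropyl on the saturated ring carbon gives a 1.2-fold higher number from compound 1 to compound 3 (0.06 log units; within the scatter) and so does not separate the two groups on this read-out. Within the data shown here, this is the first reading at this position: with the cyanoguanidine and the (4-chlorophenyl)carbamoyl group held constant, an aromatic ring on this carbon is not needed to keep the number at the level of compound 1, and a branched group with no ring serves equally well. No evidence at hand accounts for this match between the two groups.

The compounds shown leave open whether isopropyl and phenyl also match when the urea linkage of compound 2 stands in place of the cyanoguanidine. From the compounds shown here alone, how methyl, cyclohexyl, an amine or a carboxylic acid on this carbon would read is also open, so it remains unsettled whether the position accepts groups of any kind or only hydrocarbon groups such as these two.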